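A Benzyl Amide on the Shared Core

A few compounds are considered here, and "the series" means these few. Any claim that something is new, unique, unknown or untested is made for them only; others in the source may bear on it.

Compound 1, `CCCCNc1nc(N)nc2cccc(OC)c12`, is the reference point. In an ADME assay on HEK293 cells for agonist activity at Toll-like receptor 8 (Homo sapiens), read by a luciferase reporter, with a stated time of 6 h (a lower number here means that less compound is needed, a higher number that more compound is needed for the effect), compound 1 gives 0.1 uM. Compound 2, `CCCCNc1nc(N)nc2cccc(CC3CCCC3)c12`, carries a cyclopentylmethyl where compound 1 has a methoxy; in this assay compound 2 reaches only the limit of > 25 uM, a boundary of the assay rather than a number, (the limit of > 25 uM in this assay, at which 1 of the 3 values shown sits). Compound 3, `CCCCNc1nc(N)nc2cccc(C(=O)NC(C)C)c12`, carries an isopropylcarbamoyl at the same position; in this assay compound 3 gives 15.6 uM. Among the two numbers shown, compound 3 stands highest, and its nearest neighbour is compound 1, with a 160-fold higher number from compound 1 to compound 3 (2.19 log units; beyond the scatter); the matching change to the cyclopentylmethyl gave an at least 250-fold higher number from compound 1 to compound 2 (2.39 log units; beyond the scatter), while the comparison an at least 1.6-fold lower number from compound 2 to compound 3 (0.20 log units; that floor lies within the scatter) rests on a limit and lies within the scatter.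

Compound 4, `CCCCNc1nc(N)nc2cccc(C(=O)NCc3ccccc3)c12`, differs from compound 3 only at the amide: benzyl in place of isopropyl on an amide-type nitrogen. For the measured compounds named here, none of the measured steps alters this amide substituent; all three replace the methoxy of compound 1 or compare the resulting groups. The two amides therefore share their anchor, and the expected step of a 1.3-fold lower number from compound 3 to compound 4 (0.11 log units; within the scatter) is small, with no clear direction beyond the scatter. Compound 4 is estimated at 12 uM, between 4 uM and 30 uM.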

Compound 4, minimum effective concentration: 1.6 uM
The estimate for compound 4 lay 7.5-fold (0.88 log units) above the measured number; measured number below the stated range.
By their numbers in this assay, from the lowest: compound 1; then compound 4; then compound 3. At a limit, above all of these: compound 2.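

The earlier compounds shown here only replaced the methoxy of compound 1 or compared the groups that took its place, so they could not show whether the group on the amide nitrogen matters once an amide stands at this position. In this assay it does: benzyl in place of isopropyl on the amide-type nitrogen gives a step beyond the scatter (a 9.8-fold lower number from compound 3 to compound 4 (0.99 log units; beyond the scatter)), so the presence of an amide at this position does not alone settle the number, and the substituent it carries counts as well. Nothing measured here says why the change from isopropyl to benzyl, which brings in one six-membered aromatic ring of carbon only, has this effect.

The compounds shown leave open whether the ring itself is what counts, since a cyclohexylmethyl or a plain butyl chain on the amide nitrogen would separate the aromatic ring from the added carbon atoms. They also leave open how far the trend runs, for instance whether a phenethyl group, with a longer chain leading to the ring, or a benzyl ring carrying an amine or a carboxylic acid would follow benzyl or fall back towards isopropyl.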